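Working notes: amide-terminal variation on a shared core

The source may report more compounds than this note shows. Statements on the series, on what has been measured and on what is new or still open speak of the compounds shown alone.

Measured compounds:
compound 1 `NS(=O)(=O)CC(=O)NCCSc1nonc1/C(=N/O)Nc1ccc(F)c(C(F)F)c1` 73 nM
compound 2 `CC1(C(=O)NCCSc2nonc2/C(=N/O)Nc2ccc(F)c(C(F)F)c2)CCN1` 360 nM
compound 3 `O=C(NCCSc1nonc1/C(=N/O)Nc1ccc(F)c(C(F)F)c1)C1CS(=O)(=O)C1` 70 nM

In an assay for inhibition of Indoleamine 2,3-dioxygenase 1 (Homo sapiens), read by fluorescence, with a stated time of 1 h (on this read-out lower numbers stand for stronger inhibition and higher numbers for weaker inhibition), compound 3 gives the lowest of the three numbers, though compound 1 sits within the scatter of it (a 1.0-fold lower number from compound 1 to compound 3 (0.02 log units; within the scatter)); only compound 2 stands clearly apart (a 5.1-fold lower number from compound 2 to compound 3 (0.71 log units; beyond the scatter)). The unmeasured compound 4 `N#CCC(=O)NCCSc1nonc1/C(=N/O)Nc1ccc(F)c(C(F)F)c1` differs from compound 3 as follows: a group of 3 heavy atoms (2 carbon, 1 nitrogen; no ring) in place of a group of 6 heavy atoms (3 carbon, 2 oxygen, 1 sulfur; one four-membered non-aromatic ring with 1 hetero atom), on a carbonyl carbon. For the measured compounds named here, two measured steps bear on this position. a 1.0-fold lower number from compound 1 to compound 3 (0.02 log units; within the scatter) shows the ring group and an uncharged open-chain group giving the same number, while a 4.9-fold higher number from compound 1 to compound 2 (0.69 log units; beyond the scatter) shows a basic ring group costing a modest amount. Cyanomethyl is uncharged and open-chain, so no step beyond the scatter is expected from compound 3, with the estimate for compound 4 being 110 nM (range 45 nM to 280 nM), a step of a 1.6-fold higher number from compound 3 to compound 4 (0.20 log units; within the scatter).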

Compound 4, half-maximal inhibitory concentration: 180 nM
For compound 4 the middle estimate is 1.6-fold (0.21 log units) below the measured one, within the range that was stated.
By their numbers in this assay, from the lowest: compounds 3 and 1 (each within the scatter of the next); then compounds 4 and 2 (each within the scatter of the next).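

In this assay an open-chain group on the carbonyl carbon does not by itself keep the number of compound 1 or compound 3: cyano in place of sulfamoyl gives a 2.5-fold higher number from compound 1 to compound 4 (0.39 log units; beyond the scatter) and cyanomethyl in place of the ring group gives a 2.6-fold higher number from compound 3 to compound 4 (0.41 log units; beyond the scatter). Compound 4 also cannot be separated from the ring-bearing compound 2 on a 2.0-fold lower number from compound 2 to compound 4 (0.30 log units; within the scatter), so the open-chain and ring groups do not sort the values. No supporting data explain these steps. As far as these compounds go, whether a carboxylic acid or a longer alkyl chain on the carbonyl carbon would give a number like that of compound 1 or a number like that of compound 4 remains open.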